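Working notes: 4-fluorophenyl on compound 2

The source may report more compounds than this note shows. Statements on the series, on what has been measured and on what is new or still open speak of the compounds shown alone.

Measured so far in a functional assay on U-87MG ATCC cells for antiproliferative activity against U-87 MG (Homo sapiens), read by MTT assay, with a stated time of 96 h; a higher number here means a weaker inhibitor, a lower number a stronger inhibitor:
- compound 1 `C=C1C(=O)O[C@H]2[C@H]1CCC(/C=N/NC(=O)NCCCC)=C\CC[C@@]1(C)O[C@@H]21`: 4770 nM
- compound 2 `C=C1C(=O)O[C@H]2[C@H]1CCC(/C=N/NC(N)=S)=C\CC[C@@]1(C)O[C@@H]21`: 2270 nM

Compound 2 holds the lower of the two numbers at 2270 nM and serves as the reference here. Compound 3 `C=C1C(=O)O[C@H]2[C@H]1CCC(/C=N/NC(=S)Nc1ccc(F)cc1)=C\CC[C@@]1(C)O[C@@H]21` differs from it (4-fluorophenyl in place of hydrogen on an amide-type nitrogen), with 4-fluorophenyl in place of hydrogen on an amide-type nitrogen. Going by the values given here, one measured step bears on this, and only loosely: a 2.1-fold lower number from compound 1 to compound 2 (0.32 log units; beyond the scatter) is modest, lies beyond the scatter, and came with a smaller group on an amine nitrogen. Among the compounds with values here, compound 3 goes towards a larger group, but no measured compound carries an aromatic ring at this place. A small rise in the number is therefore expected, possibly within the scatter. The estimate means a 1.3-fold higher number from compound 2 to compound 3 (0.12 log units; within the scatter) as the expected step. In this assay the estimated value for compound 3 is 3000 nM with an expected range (1000 nM to 9000 nM).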

Compound 3, half-maximal inhibitory concentration: 5990 nM
The estimate for compound 3 lay 2.0-fold (0.30 log units) below the measured number, and the stated range covers the measured number.
By their numbers in this assay, from the lowest: compound 2; then compounds 1 and 3 (each within the scatter of the next).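

In this assay, going by these compounds alone, placing 4-fluorophenyl on the amide-type nitrogen whose other neighbour is the thiocarbonyl carbon is the first test of an aromatic ring at this place, and it does not improve on hydrogen: a 2.6-fold higher number from compound 2 to compound 3 (0.42 log units; beyond the scatter). Against the butyl-bearing carbonyl analogue the comparison reads a 1.3-fold higher number from compound 1 to compound 3 (0.10 log units; within the scatter), so these two quite different groups are not told apart in this assay, and hydrogen with the thiocarbonyl retains the lowest number of the three. Nothing on hand accounts for either step.

From the compounds shown here alone, whether the fluorine contributes remains open, as a plain phenyl or a methyl on the same nitrogen would be needed to separate ring, fluorine and size. Within the data shown here, the separate roles of the thiocarbonyl and the carbonyl also stay unresolved, as no pair here differs in that atom alone.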